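The compounds below may be only part of what the source reports. "The series", "measured", "known", "first", "only" and "open" are said of these compounds alone.

Three compounds of this series carry numbers in a functional assay on HL-60 cells (Homo sapiens) for antiproliferative activity, read by MTT assay, with a stated time of 72 h; on this read-out higher numbers stand for weaker inhibition and lower numbers for stronger inhibition. In this assay compound 1 `NC1=NC2(CCOCC2)N(OCCCOc2cccc(Cl)c2Cl)C(N)=N1` gives 440 nM. In this assay compound 2 `NC1=NC2(CCSCC2)N(OCCCOc2ccc(Cl)cc2)C(N)=N1` gives 430 nM. In this assay compound 3 `CC(C)(C)c1ccc(OCCCON2C(N)=NC(N)=NC23CCSCC3)cc1` gives 280 nM. Compound 2 stands second highest of the three numbers; its nearest neighbour is compound 1 and its furthest is compound 3, and both gaps lie within the scatter, so no order among the three can be read from these numbers. Going by the values given here, the only single-place step measured so far is a 1.5-fold lower number from compound 2 to compound 3 (0.19 log units; within the scatter), and that step stays within the scatter.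

Compound 4 `NC1=NC2(CCSCC2)N(OCCCOc2cc(Cl)c(Cl)cc2Cl)C(N)=N1` has not yet been measured in this assay. Against compound 2 it carries 2,4,5-trichlorophenyl in place of 4-chlorophenyl on an oxygen on a saturated carbon. Among the compounds with values here, the one measured step that touches the same aromatic ring is the change from compound 2 to compound 3, which stayed within the scatter. Nothing measured here separates a single chloro from several chloro groups on that ring. No step beyond the scatter is therefore expected in either direction, and the step expected is a 1.1-fold lower number from compound 2 to compound 4 (0.05 log units; within the scatter). Compound 4 is estimated at 380 nM, with an expected range from 150 nM to 950 nM.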

Compound 4, half-maximal inhibitory concentration: 730 nM
Estimate against measurement, compound 4: 1.9-fold (0.28 log units) below; low and high end bracket the measured number.
By their numbers in this assay, from the lowest: compounds 3, 2, 1 and 4 (each within the scatter of the next, the first and the last beyond it).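

In this assay, 2,4,5-trichlorophenyl in place of 4-chlorophenyl on an oxygen on a saturated carbon gives a 1.7-fold higher number from compound 2 to compound 4 (0.23 log units; within the scatter) and so adds two chlorine atoms to the ring without a step beyond the scatter. Together with a 1.5-fold lower number from compound 2 to compound 3 (0.19 log units; within the scatter) as the earlier change on this ring, this makes two different replacements of 4-chlorophenyl at this position, and neither leaves the scatter. Nothing available bears on the reason for this result.

The compounds shown do not separate the contributions of the two added chlorine atoms. Going by these compounds, whether an amine or a carboxylic acid on this ring, or a longer chain in place of the present one, would produce a step beyond the scatter remains open.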